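The source may report more compounds than this note shows. Statements on the series, on what has been measured and on what is new or still open speak of the compounds shown alone.

Going by the values given here, in a functional assay for agonist activity at G protein-coupled receptor 88 (Homo sapiens), read by HTRF and cAMP accumulation (on this read-out lower numbers stand for an effect already at smaller amounts and higher numbers for an effect only at larger amounts of compound), compound 3 `CN[C@@H](CC(C)C)CN(C(=O)[C@@H]1C[C@H]1c1ccccc1)c1ccc(-c2ccccc2)cc1` gives 2 nM, the only plain number among the three measured compounds. Compound 1 `CC[C@H](C)[C@H](N)CN(C(=O)[C@@H]1C[C@H]1c1ccccc1)c1ccc(-c2ccccc2)cc1` gives 230 nM; 800 nM (2 entries) in this assay across repeated entries. Compound 2 `CC(C)CCCN(C(=O)[C@@H]1C[C@H]1c1ccccc1)c1ccc(-c2ccccc2)cc1` reaches only a limit of the assay at > 100 nM, not a number. Among the compounds with values here, the one measured step, an at least 50-fold lower number from compound 2 to compound 3 (1.69 log units; beyond the scatter), shows that adding a methylamino group brings a large drop in this assay. Compound 4 `CC[C@@H](C)[C@H](N)CN(C(=O)[C@@H]1C[C@H]1c1ccccc1)c1ccc(-c2ccccc2)cc1` differs from compound 3 by 1-amino-2-methylbutyl in place of 3-methyl-1-(methylamino)butyl on a saturated chain carbon bound to an amide-type nitrogen; it carries the same amino group and branched chain as compound 1 and is therefore expected to sit near compound 1, as supported by the several entries of compound 1 in this assay, 230 nM; 800 nM (2 entries). The expected step is a 200-fold higher number from compound 3 to compound 4 (2.30 log units; beyond the scatter). Compound 4 is thus estimated at 400 nM, ranging from 100 nM to 1600 nM.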

Compound 4, half-maximal effective concentration: 1.4 nM
The estimate for compound 4 lay 290-fold (2.46 log units) above the measured number; the measured number lies below the stated range.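

With a 1.4-fold lower number from compound 3 to compound 4 (0.15 log units; within the scatter), 1-amino-2-methylbutyl serves at this place as well as 3-methyl-1-(methylamino)butyl. Against the isopentyl of compound 2, the result is an at least 71-fold lower number from compound 2 to compound 4 (1.85 log units; beyond the scatter), so the large drop seen with compound 3 appears with a second amine-bearing group. Compound 1 gives 230 nM; 800 nM (2 entries) while compound 4 gives 1.4 nM, so the drawn arrangement of this group matters greatly: the fact that compounds 1 and 4 differ only in the configuration as drawn

From the compounds shown here alone, how a hydroxyl or a dimethylamino group would fare at this place stays open. Also open, going by these compounds, is what a methylamino group would do on the chain of compound 4.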